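The source may hold more compounds than are shown below. What is called first, only, known or untested is meant among the compounds shown, and "the series" means these compounds.

Among the compounds with values here, compound 3 `Cc1c(Oc2ccccc2OCCn2ccc(=O)[nH]c2=O)cc(CC2CC2)c2ccc(C#N)cc12` holds the one measured number of this small set. Within the data shown here, in a toxicity assay on MT2 cells (Homo sapiens) for cytotoxicity, read by MTT assay (a higher number here means that more compound is tolerated, a lower number that less compound is tolerated), compound 3 gives 13000 nM, which is the only value reported as a number. Compound 1 `Cc1c(Oc2ccccc2OCCn2ccc(=O)[nH]c2=O)cc(Cl)c2ccc(C#N)cc12` reaches only a limit of the assay, > 100000 nM. Compound 2 `Cc1cc(Oc2ccccc2OCCn2ccc(=O)[nH]c2=O)c(C)c2cc(C#N)ccc12` likewise stops at a limit, > 100000 nM. Both measured steps that end at compound 3 run downward: an at least 7.6-fold lower number from compound 1 to compound 3 (0.88 log units; beyond the scatter) and an at least 7.6-fold lower number from compound 2 to compound 3 (0.88 log units; beyond the scatter). The step that the two limits leave unreadable from compound 1 to compound 2 cannot be sized because the limit of > 100000 nM in this assay, at which 2 of the 3 values shown sit, holds both of its ends.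

Compound 4 `CCOc1cc(Oc2ccccc2OCCn2ccc(=O)[nH]c2=O)c(C)c2cc(C#N)ccc12` differs from compound 3 by ethoxy in place of cyclopropylmethyl on an aromatic carbon. Among the measured compounds shown here, the steps that bear on this change are the two that brought the cyclopropylmethyl in, and in both the number fell; here that group leaves again and ethoxy enters, a group for which no measured step exists. The expectation for compound 4 is therefore a rise in this assay of a 4.6-fold higher number from compound 3 to compound 4 (0.66 log units; beyond the scatter), back toward the region where compound 1 and compound 2 sit, with a fair chance that only a limit is reported. The estimate for compound 4 in this assay is 60000 nM, expected to lie between 15000 nM and 200000 nM.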

Compound 4, half-maximal cytotoxic concentration: > 100000 nM
Compound 4: only a limit was reported (the forecaster's own chance of this, stated with the estimate: 45%); middle value at least 1.6-fold (0.22 log units) away from the limit.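

In this assay, ethoxy in place of cyclopropylmethyl on an aromatic carbon gives an at least 7.6-fold higher number from compound 3 to compound 4 (0.88 log units; beyond the scatter), so the lower number of compound 3 does not carry over to this other group of 3 heavy atoms, with no ring and 1 hydrogen-bond acceptor. At this place, ortho to a fused ring and para to a methyl group, the earlier compounds had set cyclopropylmethyl only against chloro and methyl; among the four compounds shown, cyclopropylmethyl is now the only group that gives a number rather than a limit, and chloro, methyl and ethoxy go with the limit. The steps to compound 4 from compound 1 and from compound 2 cannot be read, because both ends of each sit at a limit: the limit of > 100000 nM in this assay, at which 3 of the 4 values shown sit.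

The compounds shown do not separate the three-membered ring of cyclopropylmethyl from its carbon count, nor the oxygen of ethoxy from its chain, so it stays open which of these goes with the change in this assay. Going by these compounds, how a propyl chain or an amine at this place would stand in this assay also remains open.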